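Series notes: two anilide amides on a shared core

A few compounds are considered here, and "the series" means these few. Any claim that something is new, unique, unknown or untested is made for them only; others in the source may bear on it.

Compound 1, `CSc1cccc(NC(=O)C2CCCN(C(=O)c3cc(C(F)(F)F)cc(C(F)(F)F)c3)C2)c1`, was tested in an ADME assay on PC-3 cells (Homo sapiens) for cytotoxicity, read by WST assay, tested at 100 uM (a lower number here means less inhibition, a higher number more inhibition at the concentration tested (going by the name of the read-out)), and gives 0%. Compound 2, `CS(=O)(=O)Nc1cccc(C(=O)N2CCCC(C(=O)Nc3ccc(Cl)cc3)C2)c1`, gives in this assay a reading of 3%; the two values lie within the usual scatter of each other, so neither can be set apart from the other, and compound 1 is simply the lower of the two numbers by a margin that means nothing. Compound 3, `O=C(Nc1cccc(Oc2ccccc2)c1)C1CCCN(C(=O)c2cc(C(F)(F)F)cc(C(F)(F)F)c2)C1`, has not yet been measured in this assay. Compared with compound 1 the change is phenoxy in place of methylsulfanyl on an aromatic carbon. Among the compounds with values here, no step between two measured compounds is available to set a scale for such a change. Given that compound 1 sits at 0%, the expected step in this assay is a number 8 percentage points higher from compound 1 to compound 3 (within the scatter), judged to be small and upward if anything, not clearly beyond the scatter. For compound 3 in this assay the estimate is 8%, with a range from -5% to 30%.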

Compound 3, a percentage reported as inhibition, at one concentration (the size of the read-out at that concentration, not a potency): 1%
The estimate for compound 3 lay 7 percentage points above the measured number, and the stated range covers the measured number.
By their numbers in this assay, from the lowest: compounds 1, 3 and 2 (each within the scatter of the next).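

Phenoxy in place of methylsulfanyl on an aromatic carbon, meta to a large group, gives a number 1 percentage points higher from compound 1 to compound 3 (within the scatter) in this assay. Within the data shown here, this is the first step read at this place, and it shows that bringing in a six-membered aromatic ring of carbon only, a much larger group than methylsulfanyl, leaves compound 3 not distinguishable from compound 1 in this read-out at the one concentration tested. No measured information on hand accounts for this result.

Open, going by these compounds, is whether any group at this place gives a reading beyond the scatter of compound 1, for example an amine or a carboxylic acid on the same aromatic carbon. Also open, on these data alone, is whether phenoxy would read the same with a different acyl group on the shared core.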